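The source may report more compounds than this note shows. Statements on the series, on what has been measured and on what is new or still open speak of the compounds shown alone.

Measured so far:
Compound 1 `C=CCn1c(=O)/c(=C\c2ccc(Cl)c(Cl)c2)[nH]c(=O)/c1=C\c1ccccc1OC`: in a functional assay on Huh-7 cells (Homo sapiens) for cytotoxicity, read by CCK-8 assay, with a stated time of 72 h (a lower number here means a stronger inhibitor, a higher number a weaker inhibitor), compound 1 gives "not active" (no number reported).
Compound 2 `C=CCn1c(=O)/c(=C\c2ccccc2OC)[nH]c(=O)/c1=C\c1ccccc1OC`: in this assay compound 2 gives 21200 nM.

No number stands for compound 1; it is recorded only as not active, so its standing relative to compound 2 cannot be set in numbers. Compound 3 `C=CCn1c(=O)/c(=C\c2ccc(Cl)c(Cl)c2)[nH]c(=O)/c1=C\c1ccccc1` differs from compound 1 by a single change: hydrogen in place of methoxy on an aromatic carbon. Among the compounds with values here, no step between measured compounds covers this change, so no step size in this assay can be read from the data; starting from an inactive compound 1, no clear gain is expected, and the outcome may again be no number at all. Compound 3 is expected to give 40000 nM, within 10000 nM to 150000 nM.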

Compound 3, half-maximal inhibitory concentration: "not active" (no number reported)
Compound 3 has no reported number here, and the estimate cannot be compared.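

In this assay compound 1 and compound 3 both stand as not active without a number, so no step can be read between them. From the compounds shown here alone, whether replacing methoxy with hydrogen changes cytotoxicity stays open, and no evidence bearing on this result is available.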